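Second chloro on the shared core: expected cytotoxicity

A few compounds are considered here, and "the series" means these few. Any claim that something is new, unique, unknown or untested is made for them only; others in the source may bear on it.

Of the compounds shown here, three carry numbers so far. In a functional assay on OVCAR-5 cells (Homo sapiens) for cytotoxicity, read by sulforhodamine B assay, with a stated time of 48 h (on this read-out lower numbers stand for higher toxicity in this test and higher numbers for lower toxicity in this test), compound 1 `ClCc1ccc(Cn2cnc3c(Cl)ncnc32)cc1` gives 34700 nM, the second highest of the three numbers. Compound 2 `Nc1nc(Cl)c2ncn(Cc3ccccc3CCl)c2n1` gives 79400 nM in this assay, a higher number than compound 1, beyond the scatter. Compound 3 `ClCc1cccc(Cn2cnc3nc(Cl)nc(Cl)c32)c1` gives 6300 nM in this assay, the lowest of the three and well beyond the scatter from compound 1. Compound 3 differs from compound 1 in more than one place, so its gap cannot be tied to a single change.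

Compound 4 `ClCc1ccc(Cn2cnc3c(Cl)nc(Cl)nc32)cc1` has not been measured. It differs from compound 1 in one place: chloro in place of hydrogen on an aromatic carbon. Compound 3 likewise carries a second chloro on its core, and its low number 6300 nM is the only pointer for the direction of this step. A downward step beyond the scatter is therefore expected, a 2.9-fold lower number from compound 1 to compound 4 (0.46 log units; beyond the scatter), smaller than the gap to compound 3, since that gap rests on further differences. Compound 4 is estimated at 12000 nM, within a range from 4000 nM to 35000 nM.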

Compound 4, concentration lethal to 50% of the cells: 66100 nM
Beside the measured number, compound 4's estimate is 5.5-fold (0.74 log units) below it, outside the stated range (above it).
By their numbers in this assay, from the lowest: compound 3; then compounds 1, 4 and 2 (each within the scatter of the next, the first and the last beyond it).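

In this assay, chloro in place of hydrogen on an aromatic carbon, at the place between two ring nitrogen atoms, gives a 1.9-fold higher number from compound 1 to compound 4 (0.28 log units; within the scatter). This single change therefore does not separate compound 4 from compound 1 in this test, so at this position in this pair, a hydrogen and a chloro cannot be told apart by the read-out. No measured property at hand bears on this step.

As far as these compounds go, whether a methoxy group or a carboxylic acid at this same place would leave the number equally undisturbed remains open. For the compounds shown here, also open is whether chloro in place of hydrogen would read the same way on a compound differing elsewhere from compound 1, since only this one pair carries the change.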